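This account rests on a few compounds, and the source may have more. Where it says the series, first, only, none or still open, it means among the compounds named here.

Measured so far:
- compound 1 `c1cc(-c2cnc3cc4c(cc3n2)C2CNCC4C2)c[nH]1` — 360 nM
- compound 2 `CC(C)c1nc2cc3c(cc2o1)C1CNCC3C1` — 7.6 nM
- compound 3 `c1ccc(-c2cnc3cc4c(cc3c2)C2CNCC4C2)cc1` — 132 nM

In an assay for binding affinity to Neuronal acetylcholine receptor; alpha4/beta2 (Rattus norvegicus) (a lower number here means a stronger inhibitor, a higher number a weaker inhibitor), compound 1 gives 360 nM, the highest of the three numbers. Compound 3 stands nearest to it, and the gap between them is beyond the scatter; compound 2 stands furthest, with the lowest number of the set. Among the compounds with values here, none of these three differs from another in only one place, so no single step between measured compounds is at hand, and what the values show is only that the isopropyl-bearing compound 2 sits well below the two aryl-bearing compounds 1 and 3.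

Compound 4 `Oc1cnc2cc3c(cc2n1)C1CNCC3C1` is not yet measured. It is drawn from compound 1 by one change: hydroxy in place of 1H-pyrrol-3-yl on an aromatic carbon The hydroxy enters on the aromatic carbon next to the ring nitrogen, where the 1H-pyrrol-3-yl leaves.

Within the data shown here, the expectation is a moderate step down in this assay from compound 1 to compound 4, a 3.3-fold lower number from compound 1 to compound 4 (0.51 log units; beyond the scatter), since compound 2 with the smallest substituent gives 7.6 nM, though the series offers no direct precedent for a hydroxy here. Compound 4 is expected at 110 nM, with a range from 20 nM to 600 nM.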

Compound 4, inhibition constant: < 6 nM
Compound 4: only a limit was reported; the forecaster's own chance of this, stated with the estimate: 5%; middle value at least 18-fold (1.26 log units) from the limit.
By their numbers in this assay, from the lowest: compound 2; then compound 3; then compound 1. At a limit, below all of these: compound 4.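

In this assay compound 4 gives < 6 nM, a limit of the assay and not a number. Hydroxy in place of 1H-pyrrol-3-yl on this aromatic carbon, next to the ring nitrogen, gives an at least 60-fold lower number from compound 1 to compound 4 (1.77 log units; beyond the scatter), so the five-membered aromatic ring is not needed at this position for strong binding in this assay, and its presence in compound 1 goes with the weaker number. The step has a known minimum but no known full size: the limit of < 6 nM in this assay, at which 1 of the 4 values shown sits.

The compounds shown do not separate the loss of 1H-pyrrol-3-yl from any contribution of the hydroxy itself. A methoxy, an amine or a plain hydrogen on the same carbon would bear on that question, and a value measured without a limit would fix the size of the step.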